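This account rests on a few compounds, and the source may have more. Where it says the series, first, only, none or still open, it means among the compounds named here.

Measured compounds:

Compound 1, `O=C(O)Cc1sc(C(c2ccccc2)c2ccc(F)cc2)nc1-c1ccc(Cl)cc1`, gives 36 nM in an in vitro functional assay on HEK285-7 cells for antagonist activity at prostaglandin D2 receptor 2 (Homo sapiens), read by BRET and beta-arrestin recruitment; on this read-out higher numbers stand for weaker inhibition and lower numbers for stronger inhibition.
Compound 2, `O=C(O)Cc1sc(C(c2ccc(F)cc2)c2ccc(F)cc2)nc1-c1ccc(Cl)cc1`, gives 180 nM in this assay.
Compound 3, `O=C(O)Cc1sc(C(c2ccccc2)c2ccccc2)nc1-c1ccccc1`, gives 370 nM in this assay.

Compound 1 and compound 2 differ in one place only: fluoro in place of hydrogen on an aromatic carbon. That single change produced a 5.0-fold higher number from compound 1 to compound 2 (0.70 log units; beyond the scatter), so the fluorinated compound 2 inhibits less strongly than compound 1.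

Compound 3 stands on a different core, and how its core differs from that of compound 1 is not broken down here; their values alone show that compound 3 gives a higher number than compound 1, and also a higher number than compound 2, so compound 3 is the weakest inhibitor of the three measured.

Compound 4, `O=C(O)Cc1sc(C(c2ccccc2)c2ccccc2)nc1-c1ccc(F)cc1`, has not yet been measured. It differs from compound 3 in one place: fluoro in place of hydrogen on an aromatic carbon. Among the measured compounds shown here, this is the same change as the one from compound 1 to compound 2, made on the core of compound 3 instead.

In this assay, from the compounds shown here alone, the step from compound 3 to compound 4 is expected to be a 1.9-fold higher number from compound 3 to compound 4 (0.28 log units; within the scatter), which rests on the earlier step of a 5.0-fold higher number from compound 1 to compound 2 (0.70 log units; beyond the scatter), while allowing that the change now sits on a different core whose behaviour toward fluorine is unknown. For compound 4 the expected value is therefore 700 nM, with a range from 180 nM to 2800 nM.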

Compound 4, half-maximal inhibitory concentration: 77 nM
Beside the measured number, compound 4's estimate is 9.1-fold (0.96 log units) above it; measured number below the stated range.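

In this assay, putting fluoro in place of hydrogen, here a phenyl to 4-fluorophenyl change, gave a 4.8-fold lower number from compound 3 to compound 4 (0.68 log units; beyond the scatter), so compound 4 inhibits more strongly than compound 3. This means the effect of this change did not carry from one core to the other in this series, since a swap that weakened inhibition on the core of compound 1 strengthened it on the core of compound 3, and the two steps differ by more than repeated measurements would explain: the same change on two cores in this assay, a 5.0-fold higher number (0.70 log units; beyond the scatter) from compound 1 to compound 2 and a 4.8-fold lower number (0.68 log units; beyond the scatter) from compound 3 to compound 4, 24-fold (1.38 log units) apart, beyond the scatter of two such steps. Among the compounds shown here, it does not show why the direction reversed, because each core offers only one pair of compounds, and these two pairs cannot tell which of the differences between the cores matters or how a further core would respond.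

The compounds shown leave open whether the stronger inhibition on the core of compound 3 is particular to fluoro or would also appear with a different group on the same aromatic carbon, such as methyl, methoxy or trifluoromethyl. They also leave open whether a third core would follow compound 1 and compound 2, follow compound 3 and compound 4, or show neither pattern.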